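This account rests on a few compounds, and the source may have more. Where it says the series, first, only, none or still open, it means among the compounds named here.

Compound 1, `COc1ccc(-c2cn3ccnc3c(-c3ccc4ncn(C5CCCCC5)c4c3)n2)cc1`, gives 87.2% in a functional assay on NCI/ADR-RES cells (Homo sapiens) for inhibition, read by sulforhodamine B assay, with a stated time of 48 h, tested at 10 uM; on this read-out higher numbers stand for more inhibition at the one concentration tested (going by the name of the read-out) and lower numbers for less inhibition; compound 2, `Fc1ccc(-c2cn3ccnc3c(-c3ccc4ncn(C5CCCCC5)c4c3)n2)cc1`, gives 0.69%; compound 3, `COc1ccccc1-c1cn2ccnc2c(-c2ccc3ncn(C4CCCCC4)c3c2)n1`, gives 0.06%.

The change fluoro in place of methoxy on an aromatic carbon produced a number 86.5 percentage points lower from compound 1 to compound 2 (beyond the scatter). The same kind of change is now made on a different core: compound 3 differs from compound 1 by 2-methoxyphenyl in place of 4-methoxyphenyl on an aromatic carbon, and in compound 3 the group to be exchanged sits ortho to a large group, whereas in compound 1 it sat para to a large group. Compound 4, `Fc1ccccc1-c1cn2ccnc2c(-c2ccc3ncn(C4CCCCC4)c3c2)n1`, carries fluoro in place of methoxy on an aromatic carbon. Since compound 3 already gives 0.06% and compound 2, the other fluoro compound, gives 0.69%, the earlier large step is not expected to recur; the expected step is a number 2.9 percentage points higher from compound 3 to compound 4 (within the scatter), within the scatter. Compound 4 is therefore estimated at 3% in this assay, between 0% and 15%.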

Compound 4, a percentage reported as inhibition, at one concentration (the size of the read-out at that concentration, not a potency): 4.51%
The estimate for compound 4 lay 1.5 percentage points below the measured number; the range from low to high includes it.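

Fluoro in place of methoxy did not behave alike on the two arrangements in this assay: the same change on two cores in this assay, a number 86.5 percentage points lower (beyond the scatter) from compound 1 to compound 2 and a number 4.5 percentage points higher (within the scatter) from compound 3 to compound 4, 91 percentage points apart, beyond the scatter of two such steps

The new step reads a number 4.5 percentage points higher from compound 3 to compound 4 (within the scatter), the shift of fluoro gives a number 3.8 percentage points higher from compound 2 to compound 4 (within the scatter), and a number 82.7 percentage points lower from compound 1 to compound 4 (beyond the scatter), so compound 1 stands apart from the other three. This does not show why the two steps differ, and compound 3 starts so low, at 0.06%, that little further fall could be read from it, while a single pair on each side makes no rule for the series.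

The compounds shown leave open whether an amine or a longer chain such as ethoxy, in place of the methoxy of compound 1, would keep its high number.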